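The source may report more compounds than this note shows. Statements on the series, on what has been measured and on what is new or still open speak of the compounds shown alone.

Measured so far: compound 1 `Cn1c(-c2cccc(F)c2)nnc1S(C)(=O)=O`, compound 2 `CSc1nnc(-c2cccc3ccccc23)n1C` and compound 3 `Cn1c(-c2cccc3ccccc23)nnc1S(C)(=O)=O`.

In a functional assay on the whole organism for antagonist activity, with Mus musculus as the target (a lower number here means that less compound is needed, a higher number that more compound is needed for the effect), compound 1 gives > 200 mg/kg, which is a limit of the assay and not a number. In this assay compound 2 gives > 200 mg/kg, again a limit. In this assay compound 3 gives > 200 mg/kg, also a limit. The change from compound 3 to compound 2 is methylsulfanyl in place of methylsulfonyl on an aromatic carbon; the step it made is a step that the two limits leave unreadable from compound 3 to compound 2, unreadable due to the limit of > 200 mg/kg in this assay, at which 3 of the 3 values shown sit. Compound 4 `CSc1nnc(-c2cccc(F)c2)n1C` has not yet been measured. It differs from compound 1 by methylsulfanyl in place of methylsulfonyl on an aromatic carbon, the same kind of change; around the place the ring atom bears a group of 7 heavy atoms in compound 1, where compound 3 has a large group there. The difference between the two cores of compound 1 and compound 3 is not broken down here. Within the data shown here, since the only measured step of this kind gives no size and compound 1 itself sits at a limit, the expectation rests on that limit. Compound 4 is expected to give 300 mg/kg, with a range from 150 mg/kg to 1000 mg/kg. This estimate means a step that the limit leaves unreadable from compound 1 to compound 4.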

Compound 4, dose for half-maximal effect: > 200 mg/kg
Compound 4 ended at the assay's limit (the forecaster's own chance of this, stated with the estimate: 85%); the middle value lies beyond the limit too.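

Compound 4 stays at a limit of the assay, just as compound 1 does, so no size can be read for the change from methylsulfonyl to methylsulfanyl between compound 1 and compound 4, for this reason: the limit of > 200 mg/kg in this assay, at which 4 of the 4 values shown sit. The compounds shown leave open whether that change alters the dose needed in this assay at all.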